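A few compounds are considered here, and "the series" means these few. Any claim that something is new, unique, unknown or untested is made for them only; others in the source may bear on it.

Three compounds share one core: a carbonyl carbon joined on one side to a saturated chain and on the other to a five-membered heteroaromatic ring, and the ring is the only thing that varies. Compound 1 `Cn1nnc(C(=O)CCCCCCc2ccccc2)n1` carries a 2-methyl-2H-tetrazol-5-yl ring; in an assay on HEK-293T cells for inhibition of diacylglycerol lipase-alpha (Homo sapiens), read by colorimetric assay (a higher number here means a weaker inhibitor, a lower number a stronger inhibitor), compound 1 gives only a limit of the assay, > 10000 nM. Compound 2 `O=C(CCCCCCc1ccccc1)c1nc(Br)co1` carries a 4-bromo-1,3-oxazol-2-yl ring, and in this assay compound 2 likewise gives a limit, > 10000 nM. Compound 3 `O=C(CCCCCCc1ccccc1)c1ncno1` carries a 1,2,4-oxadiazol-5-yl ring, and in this assay compound 3 gives a limit as well, > 10000 nM. Compound 3 thus stands at the limit of > 10000 nM in this assay, at which 3 of the 3 values shown sit, with no number to set it against the other two. The steps a step that the two limits leave unreadable from compound 1 to compound 2, a step that the two limits leave unreadable from compound 1 to compound 3 and a step that the two limits leave unreadable from compound 2 to compound 3 are all unreadable for the same reason.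

Compound 4 `O=C(CCCCCCc1ccccc1)c1ncc(Cl)o1` is the next member: 5-chloro-1,3-oxazol-2-yl in place of 1,2,4-oxadiazol-5-yl on a carbonyl carbon. Among the measured compounds shown here, the one measured step that bears on this change is a step that the two limits leave unreadable from compound 2 to compound 3, which exchanges the 4-bromo-1,3-oxazol-2-yl ring for the 1,2,4-oxadiazol-5-yl ring and shows no size or direction. Nothing in the series gives a readable trend. The expectation is that compound 4 in this assay remains at the limit, so the expected step of a number no higher from compound 3 to compound 4 (the limit leaves the size open) is taken as none beyond the scatter. The estimate for compound 4 is 10000 nM, within 3000 nM to 30000 nM, most likely reported as a limit again.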

Compound 4, half-maximal inhibitory concentration: > 10000 nM
Compound 4: a limit, no number; the forecaster's own chance of this, stated with the estimate: 75%; the middle value lies on the limit itself.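

In this assay compound 4 gives > 10000 nM, which is a limit and not a number. No step from compound 1, compound 2 or compound 3 to compound 4 can be read, and the series sits at one value: the limit of > 10000 nM in this assay, at which 4 of the 4 values shown sit.

The compounds shown leave open whether any ring on the shared core gives a numerical inhibitory concentration, and how the four rings rank.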